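Chloro for Methyl: Expected Cytotoxicity of Compound 4

The source may report more compounds than this note shows. Statements on the series, on what has been measured and on what is new or still open speak of the compounds shown alone.

Measured so far:
Compound 1 `CCN(CC)CN1C(=O)/C(=N\NC(=S)NO)c2cc(Cl)ccc21` gives 562000 nM in an ADME assay on MT4 cells (Homo sapiens) for cytotoxicity, read by spectrophotometry, with a stated time of 5 days; a lower number here means that less compound is tolerated, a higher number that more compound is tolerated.
Compound 2 `CONC(=S)N/N=C1\C(=O)N(CN2CCN(c3ccccc3)CC2)c2ccc(C)cc21` gives 276000 nM.
Compound 3 `CCN(CC)CN1C(=O)/C(=N\NC(=S)NO)c2cc(C)ccc21` gives 534000 nM.

Compound 3 and compound 1 differ in one place:

chloro in place of methyl on an aromatic carbon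

That change produced a 1.1-fold higher number from compound 3 to compound 1 (0.02 log units; within the scatter). Compound 4 `CONC(=S)N/N=C1\C(=O)N(CN2CCN(c3ccccc3)CC2)c2ccc(Cl)cc21`, not yet measured, differs from compound 2 in the following way:

chloro in place of methyl on an aromatic carbon

The place is described in exactly the same words as for the change from compound 3 to compound 1, so this is the same change made on a different core. How the core of compound 2 differs from the core of compound 3 is not broken down here. Because a 1.1-fold higher number from compound 3 to compound 1 (0.02 log units; within the scatter) was small, the step from compound 2 to compound 4 is expected to be similar, namely a 1.1-fold higher number from compound 2 to compound 4 (0.04 log units; within the scatter). Compound 4 is therefore estimated at 300000 nM, with a likely range from 150000 nM to 600000 nM.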

Compound 4, half-maximal cytotoxic concentration: 267000 nM
Estimate against measurement, compound 4: 1.1-fold (0.05 log units) above; the range from low to high includes it.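

In this assay, chloro in place of methyl gives a 1.0-fold lower number from compound 2 to compound 4 (0.01 log units; within the scatter) on the core of compound 2, so the swap leaves the number within the usual scatter. Set beside the earlier case on the other core, the two steps agree: the same change on two cores in this assay, a 1.1-fold higher number (0.02 log units; within the scatter) from compound 3 to compound 1 and a 1.0-fold lower number (0.01 log units; within the scatter) from compound 2 to compound 4, 1.1-fold (0.04 log units) apart, within the scatter of two such steps

The small effect of this change therefore carried over between these two cores, but two pairs cannot show that it would stay small on any other core or in any other kind of test.

The compounds shown carry only methyl or chloro at this place on the ring. As far as these compounds go, what a methoxy group, a nitrile or an amine would do there remains open.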